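The compounds below may be only part of what the source reports. "The series", "measured", "known", "first", "only" and "open" are said of these compounds alone.

Measured in a functional assay on HT-29 cells (Homo sapiens) for inhibition, read by sulforhodamine B assay, with a stated time of 48 h; on this read-out lower numbers stand for stronger inhibition of growth and higher numbers for weaker inhibition of growth:
Compound 1 `c1cc(NC2=NCCO2)cc(OC2CCCCC2)c1`: 4400 nM
Compound 2 `c1ccc(COc2ccc(NC3=NCCO3)cc2)cc1`: 10300 nM

Of these two, compound 2 has the higher number, and so the weaker inhibition of growth, and the gap to compound 1 lies beyond the usual scatter. Compound 3 `O=C(CCl)NC(=O)Nc1ccc(OCc2ccccc2)cc1` has not yet been measured. It differs from compound 2 in one place: a group of 7 heavy atoms (3 carbon, 1 nitrogen, 2 oxygen, 1 chlorine; no ring) in place of a group of 5 heavy atoms (3 carbon, 1 nitrogen, 1 oxygen; one five-membered non-aromatic ring with 2 hetero atoms), on a nitrogen on an aromatic ring. For the measured compounds named here, no pair of measured compounds differs in only one place, so no measured step bears on this change, and the expectation is a judgment from the structural change alone. In this assay, a modest move towards a lower number is expected, only slightly beyond the scatter. The estimated step is a 2.6-fold lower number from compound 2 to compound 3 (0.41 log units; beyond the scatter). The estimated value for compound 3 is 4000 nM, with an expected range of 1300 nM to 12000 nM.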

Compound 3, concentration for 50% growth inhibition: 2600 nM
The estimate for compound 3 lay 1.5-fold (0.19 log units) above the measured number; low and high end bracket the measured number.
By their numbers in this assay, from the lowest: compounds 3 and 1 (each within the scatter of the next); then compound 2.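

Putting the open-chain ((chloromethyl)carbonyl)carbamoyl group in place of the five-membered non-aromatic ring, on a nitrogen on an aromatic ring, gives a 4.0-fold lower number from compound 2 to compound 3 (0.60 log units; beyond the scatter) in this assay. For the compounds shown here, this is the first step that reads a change at this place, as the two earlier compounds differ in more than one place. For this pair, the ring is not needed for growth inhibition, and the open-chain group does better, though nothing available explains the step.

Going by these compounds, it remains open which part of the entering group carries the gain, and whether a methyl, a bromomethyl or a longer chain in place of the chloromethyl would keep it. On these data alone, it is also open whether the same exchange on the core of compound 1 would give a step of similar size.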